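A few compounds are considered here, and "the series" means these few. Any claim that something is new, unique, unknown or untested is made for them only; others in the source may bear on it.

Series notes. Compound 1 `CC(Oc1ccccc1-c1ccccc1)C1=NCCO1` and compound 2 `CC(Oc1ccccc1-c1ccccc1)C1=NCCS1` share one core and differ only in the ring attached to the chain carbon. In a functional assay on CHO cells for agonist activity at Alpha-2B adrenergic receptor (Homo sapiens) (a higher number here means a larger maximal response, a lower number a smaller maximal response), compound 1 gives < 0.3, which is a limit of the assay and not a number. In this assay compound 2 gives < 0.3, likewise a limit. For the measured compounds named here, the step that the two limits leave unreadable from compound 1 to compound 2 is therefore unreadable in size and direction; the only evidence bearing on it is the limit of < 0.3 in this assay, at which 2 of the 2 values shown sit. Compound 2 thus stands at the limit in this assay, with no number to place it more exactly.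

Compound 3 `CC(Oc1ccccc1-c1ccccc1)C1=NCCC1` is not yet measured. It differs from compound 2 by a group of 5 heavy atoms (4 carbon, 1 nitrogen; one five-membered non-aromatic ring with 1 hetero atom) in place of a group of 5 heavy atoms (3 carbon, 1 nitrogen, 1 sulfur; one five-membered non-aromatic ring with 2 hetero atoms), on a saturated chain carbon bound to an oxygen on an aromatic ring and a saturated chain carbon. Going by the values given here, no measured step bears on this change directly, and the one step available, a step that the two limits leave unreadable from compound 1 to compound 2, cannot be read. With both measured values at the limit, the expected step is a step that the limit leaves unreadable from compound 2 to compound 3, nothing beyond the scatter. Compound 3 is estimated in this assay at 0.2, expected between 0.05 and 0.4, most likely reported again as a limit.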

Compound 3, intrinsic activity: the largest response reached, as a fraction of the reference agonist's: < 0.3
Compound 3: only a limit was reported (the forecaster's own chance of this, stated with the estimate: 70%); the middle value lies beyond the limit too.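

No new step can be read among compound 1, compound 2 and compound 3 in this assay, because all three values are limits and not numbers: the limit of < 0.3 in this assay, at which 3 of the 3 values shown sit.

Still open, going by these compounds, is whether changing the ring on the saturated chain carbon alters the maximal response at all, and in which direction.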